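Benzyl in place of 2,4-dichlorobenzyl on compound 1

The source may hold more compounds than are shown below. What is called first, only, known or untested is meant among the compounds shown, and "the series" means these compounds.

Measured so far:
Compound 1 `CC1CCN(Cc2ccc3nc(NC(=O)N/N=C/c4cn(Cc5ccc(Cl)cc5Cl)c5ccccc45)sc3c2)CC1`: 1660 nM
Compound 2 `CCN(CC)Cc1ccc2nc(NC(=O)N/N=C/c3cn(Cc4ccc(Cl)cc4Cl)c4ccccc34)sc2c1`: 1080 nM
Compound 3 `CN(C)Cc1ccc2nc(NC(=O)N/N=C/c3cn(Cc4ccc(Cl)cc4Cl)c4ccccc34)sc2c1`: 950 nM

In a functional assay on NCI-H460 cells (Homo sapiens) for cytotoxicity, read by MTT assay, with a stated time of 72 h (a higher number here means a weaker inhibitor, a lower number a stronger inhibitor), compound 1 gives 1660 nM, the highest of the three numbers, though only by small margins: a 1.5-fold lower number from compound 1 to compound 2 (0.19 log units; within the scatter) and a 1.7-fold lower number from compound 1 to compound 3 (0.24 log units; within the scatter), both within the scatter, as is a 1.1-fold lower number from compound 2 to compound 3 (0.06 log units; within the scatter). The three compounds therefore cannot be ranked against each other on these numbers.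

Compound 4 `CC1CCN(Cc2ccc3nc(NC(=O)N/N=C/c4cn(Cc5ccccc5)c5ccccc45)sc3c2)CC1` is the unmeasured compound. It differs from compound 1 at a different place from every measured step: phenyl in place of 2,4-dichlorophenyl on a saturated chain carbon bound to an aromatic nitrogen. All three measured steps alter the amine on the saturated chain carbon bound to an aromatic carbon and leave the 2,4-dichlorobenzyl untouched, so none of them bears on this change, and nothing measured here says how large it will be or in which direction.

With no measured guide, the estimate is centred near compound 1 and carries a wide range: for compound 4 the expected step is a 1.5-fold higher number from compound 1 to compound 4 (0.18 log units; within the scatter), giving an expected value of 2500 nM, somewhere between 800 nM and 8000 nM.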

Compound 4, half-maximal inhibitory concentration: 1910 nM
For compound 4 the middle estimate is 1.3-fold (0.12 log units) above the measured one; the range from low to high includes it.
By their numbers in this assay, from the lowest: compounds 3, 2, 1 and 4 (each within the scatter of the next).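

In this assay, taking both chlorine atoms off the 2,4-dichlorobenzyl group to leave benzyl gives a 1.2-fold higher number from compound 1 to compound 4 (0.06 log units; within the scatter), so the two groups cannot be told apart here. Among the compounds shown here, the earlier compounds varied only the amine, so this is the first look at the group on the saturated chain carbon bound to an aromatic nitrogen. With the 4-methylpiperidin-1-yl amine kept, the chlorine atoms make no difference that can be read in this assay, and no supporting data are available to explain the result.

Going by these compounds, it remains open whether benzyl behaves the same way alongside the dimethylamino or diethylamino amines. On these data alone, it is also open whether a methoxy group on the phenyl ring, or a longer chain such as 2-phenylethyl in place of benzyl, would move the number beyond the scatter.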